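The source may hold more compounds than are shown below. What is called first, only, known or untested is meant among the compounds shown, and "the series" means these compounds.

Compound 2, with the structure `COc1ccc(NC(=O)COc2cc(C)nc3ccc(OC)cc23)cc1`, holds the higher of the two solubility values in hand: in a physicochemical assay for solubility, in phosphate buffer, measured as kinetic solubility, with a stated time of 1 h, at pH 7.4 (on this read-out higher numbers stand for higher solubility and lower numbers for lower solubility), compound 2 gives 108000 nM, while compound 1, `COc1ccc2nc(C)c(NC(=O)C(=O)Nc3cc(C)cc(C)c3)c(O)c2c1`, gives 10000 nM in this assay. Compound 3, `COc1ccc2nc(C)cc(OCC(=O)Nc3nccs3)c2c1`, has not been measured. It departs from compound 2 by 1,3-thiazol-2-yl in place of 4-methoxyphenyl on an amide-type nitrogen. Within the data shown here, no measured pair shows this change, so its effect in this assay is open. Since only the values of compounds 1 and 2 are known, the step is expected to be modest, perhaps a slight decrease, and is estimated as a 1.5-fold lower number from compound 2 to compound 3 (0.19 log units; within the scatter). Compound 3 is expected to give about 70000 nM, within 20000 nM to 250000 nM.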

Compound 3, solubility: 54000 nM
Estimate against measurement, compound 3: 1.3-fold (0.11 log units) above; measured number inside the range.
By their numbers in this assay, from the lowest: compound 1; then compounds 3 and 2 (each within the scatter of the next).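

In this assay, among these compounds, the change to 1,3-thiazol-2-yl from 4-methoxyphenyl on an amide-type nitrogen gives a 2.0-fold lower number from compound 2 to compound 3 (0.30 log units; within the scatter) and is the first reading at this position. A six-membered aromatic ring of carbon only can thus give way here to a five-membered aromatic ring with 2 hetero atoms without a step beyond the scatter. Nothing measured speaks to the cause of this step. As far as these compounds go, whether a pyridine ring, an open-chain amine or a carboxylic acid on this nitrogen would give a step beyond the scatter remains open.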